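Notes on one substituent change in a bile acid receptor series

The source may hold more compounds than are shown below. What is called first, only, known or untested is meant among the compounds shown, and "the series" means these compounds.

Measured so far:
compound 1, `COc1cccc(Cn2cc(C(=O)Nc3ccc(C)c(S(=O)(=O)N4CCOCC4)c3)c(C(C)C)n2)c1`, 199 nM
compound 2, `COc1cccc(Cn2cc(C(=O)Nc3ccc(C)c(S(=O)(=O)N4CCOCC4)c3)c(-c3cccc(OC)c3)n2)c1`, 42.8 nM

Both numbers come from an assay on isolated protein for antagonist activity at Bile acid receptor (Homo sapiens), read by TR-FRET, with a stated time of 20 min; on this read-out higher numbers stand for weaker inhibition and lower numbers for stronger inhibition. Going by the values given here, compound 2 holds the lower of the two values, and the only measured step is a 4.6-fold lower number from compound 1 to compound 2 (0.67 log units; beyond the scatter), where a 3-methoxyphenyl stands in place of an isopropyl on the same aromatic carbon of the shared core. Compound 3, `COCCc1nn(Cc2cccc(OC)c2)cc1C(=O)Nc1ccc(C)c(S(=O)(=O)N2CCOCC2)c1`, has not been measured in this assay. It differs from compound 2 by 2-methoxyethyl in place of 3-methoxyphenyl on an aromatic carbon.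

Among the compounds with values here, the one measured step bears on this change only by analogy: it shows that exchanging a small branched alkyl for the 3-methoxyphenyl at this position lowered the number beyond the scatter. The 2-methoxyethyl group that enters is again a small chain without a ring, closer in that respect to the isopropyl of compound 1 than to the aryl of compound 2. A step back upward, of a size comparable to the measured step, is therefore expected rather than no change. For compound 3 the expected value is 150 nM, with a range from 60 nM to 400 nM. The step this estimate implies is expected to be a 3.5-fold higher number from compound 2 to compound 3 (0.54 log units; beyond the scatter).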

Compound 3, half-maximal inhibitory concentration: 390 nM
Estimate against measurement, compound 3: 2.6-fold (0.41 log units) below; the measured number falls inside the stated range.
By their numbers in this assay, from the lowest: compound 2; then compounds 1 and 3 (each within the scatter of the next).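

In this assay, replacing the 3-methoxyphenyl with 2-methoxyethyl on this aromatic carbon gives a 9.1-fold higher number from compound 2 to compound 3 (0.96 log units; beyond the scatter), so compound 2 now stands apart from both compounds without a ring here, not only from compound 1. The leaving and entering groups carry the same count of hydrogen-bond acceptors, so that count alone does not keep the lower number, while the two ringless groups are not separated: a 2.0-fold higher number from compound 1 to compound 3 (0.29 log units; within the scatter). Nothing available explains why the aryl group gives the lower number.

Three compounds cannot tell whether the value of compound 2 belongs to the aromatic ring as such or to the methoxy group it carries, and a plain phenyl or a pyridine ring on this carbon would separate those two readings. From the compounds shown here alone, it also remains open whether a longer ether chain, or a chain ending in an amine or a carboxylic acid, would stay level with compound 1 and compound 3 or come closer to compound 2.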